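This account rests on a few compounds, and the source may have more. Where it says the series, first, only, none or still open, it means among the compounds named here.

Of the compounds shown here, two have so far been measured in an assay on isolated protein for inhibition of aldehyde dehydrogenase 1A1 (Homo sapiens), read by spectrophotometry, tested at 10 uM; on this read-out higher numbers stand for more inhibition at the one concentration tested (going by the name of the read-out) and lower numbers for less inhibition. Compound 1 `Cc1ccc(Cn2c(CN3CCN(C(=O)C4CC4)CC3)nc3ccccc32)cc1` gives 51.5% in this assay, the higher of the two numbers. Compound 2 `CC(C)CCn1c(OC2CCN(C(=O)c3ccco3)CC2)nc2ccccc21` gives 30.8% in this assay. The two structures differ in several places at once, so only their two values can be set side by side, and compound 1 lies well above compound 2, beyond the scatter of the read-out. Among the compounds with values here, no step between measured compounds that differ in a single place is available.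

The step examined here leads from compound 1 to compound 3 `O=C(C1CC1)N1CCN(Cc2nc3ccccc3n2Cc2ccc(C(F)(F)F)cc2)CC1`. The change is trifluoromethyl in place of methyl on an aromatic carbon. Within the data shown here, nothing among the measured compounds shows how this change behaves in this assay, so the expectation rests on compound 1 alone. Because compound 1 gives 51.5% and the change exchanges one group for another on the same aromatic carbon, the step is expected to stay within the scatter, with at most a slight movement upward. The expected step is a number 3.5 percentage points higher from compound 1 to compound 3 (within the scatter). Compound 3 is therefore estimated at 55% in this assay, within a range from 35% to 72%.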

Compound 3, a percentage reported as inhibition, at one concentration (the size of the read-out at that concentration, not a potency): 37%
The estimate for compound 3 lay 18 percentage points above the measured number, within the range that was stated.
By their numbers in this assay, from the lowest: compounds 2 and 3 (each within the scatter of the next); then compound 1.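

In this assay, within the data shown here, the position carrying the 4-methylphenyl group proves sensitive to what sits on it: moving from 4-methylphenyl to 4-(trifluoromethyl)phenyl gives a number 14.5 percentage points lower from compound 1 to compound 3 (beyond the scatter) and thus supplies the first step in this set that differs in a single place. The earlier compounds shown here could not show this, since they differ in several places at once, whereas this pair ties a drop in the number to one aromatic carbon, para to a large group, with the rest of the structure held constant. The data at hand offer no measurement that bears on why this exchange lowers the number.

On these data alone, whether other groups on this aromatic carbon, such as a chlorine atom, a methoxy group or a carboxylic acid, would stay level with compound 1 or fall as compound 3 does remains open, and a single pair cannot show a trend across such groups. As far as these compounds go, it is also open whether the same exchange would act alike if the cyclopropyl carbonyl group at the far end of the piperazine-bearing side of compound 1 gave way to another acyl group, such as an acetyl group.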